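This account rests on a few compounds, and the source may have more. Where it says the series, first, only, none or still open, it means among the compounds named here.

Of the compounds shown here, three have been tested in a functional assay on HeLa cells (Homo sapiens) for inhibition, read by cell counting, with a stated time of 4 days; on this read-out higher numbers stand for weaker inhibition and lower numbers for stronger inhibition. Compound 1, `C=C(Br)C(=O)Nc1cccc(-c2cn3nc(-c4ccc(OC)c(OC)c4)sc3n2)c1`, gives 610 nM and stands lowest of the three numbers, so on this read-out it is the strongest inhibitor of the set. Going by the values given here, compound 2, `Nc1cccc(-c2cn3nc(Cc4ccc(Cl)cc4)sc3n2)c1`, gives 25000 nM, and compound 3, `CCc1ccc(-c2nn3cc(-c4cccc(N)c4)nc3s2)cc1`, gives 8100 nM; both of these numbers lie well above that of compound 1, beyond the usual scatter of repeated measurements, and each of them carries a free amine where compound 1 carries the bromoacrylamide, though no single-point step connects them to compound 1, so only the bare values can be compared.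

The next compound, compound 4, `C=C(Br)C(=O)Nc1cccc(-c2cn3nc(-c4cccc(OC)c4)sc3n2)c1`, differs from compound 1 in one place: hydrogen in place of methoxy on an aromatic carbon. One of the two methoxy groups of compound 1 is removed, so that the 3,4-dimethoxyphenyl becomes a 3-methoxyphenyl; the bromoacrylamide and the shared core are unchanged.

Among the compounds with values here, no step of this kind has been measured within the set, so there is nothing to calibrate it against. A small loss is expected, with a step of a 1.5-fold higher number from compound 1 to compound 4 (0.17 log units; within the scatter) that may well fall inside the scatter. Compound 4 is estimated at 900 nM, with a likely range from 300 nM to 2700 nM.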

Compound 4, half-maximal inhibitory concentration: 1100 nM
For compound 4 the middle estimate is 1.2-fold (0.09 log units) below the measured one; the range from low to high includes it.
By their numbers in this assay, from the lowest: compounds 1 and 4 (each within the scatter of the next); then compound 3; then compound 2.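

In this assay, going by these compounds alone, replacing methoxy with hydrogen on this aromatic carbon, ortho to a methoxy group and para to a large group, gives a 1.8-fold higher number from compound 1 to compound 4 (0.26 log units; within the scatter) and this is the first single-change comparison in the set. The 3,4-dimethoxyphenyl and 3-methoxyphenyl compounds therefore cannot be told apart on this read-out, so in this one pair the methoxy group at this position is not needed for inhibition in the range measured. No independent measurement is available to explain this result.

Still open, as far as these compounds go, is whether a hydroxyl, a fluorine or an ethoxy group on this same carbon would read the same way, and whether the remaining methoxy group could also be replaced by hydrogen. Also open, from the compounds shown here alone, is what the bromoacrylamide adds compared with a free amine on a molecule that otherwise matches compound 1 or compound 4.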